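Ethoxymethyl in Place of Hydroxymethyl: An Expected Cytotoxicity Step

This account rests on a few compounds, and the source may have more. Where it says the series, first, only, none or still open, it means among the compounds named here.

Compound 1 `CCCOC(=O)c1c(C)coc1-c1ccc2c(CC)cccc2c1OC` carries a propoxycarbonyl group on its furan-bearing core. In a functional assay on KBVIN cells (Homo sapiens) for cytotoxicity, read by MTT assay, with a stated time of 72 h (a higher number here means that more compound is needed for the effect, a lower number that less compound is needed), compound 1 gives only a limit, > 10 ug/mL, so no number is known for it. Compound 2 `CCc1cccc2c(OC)c(-c3occ(C)c3CO)ccc12`, in which a hydroxymethyl stands in place of that propoxycarbonyl, gives 6.6 ug/mL in this assay. The step of an at least 1.5-fold lower number from compound 1 to compound 2 (0.18 log units; that floor lies within the scatter) rests on the limit of > 10 ug/mL in this assay, at which 1 of the 2 values shown sits, and is therefore a floor rather than a measured size. Compound 2 thus holds the only number shown, the other value being a limit.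

Compound 3 `CCOCc1c(C)coc1-c1ccc2c(CC)cccc2c1OC` differs from compound 2 by ethyl in place of hydrogen on an oxygen on a saturated carbon. Among the compounds with values here, no measured step touches this oxygen; the one measured step changes a different group and is itself only a floor within the scatter. No step beyond the scatter is therefore expected. The expected step is a 1.1-fold higher number from compound 2 to compound 3 (0.03 log units; within the scatter). Compound 3 is accordingly estimated at 7 ug/mL, within 3 ug/mL to 15 ug/mL.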

Compound 3, concentration for half-maximal effect: > 10 ug/mL
Compound 3 ended at the assay's limit; the forecaster's own chance of this, stated with the estimate: 30%; at least 1.4-fold (0.15 log units) between middle value and limit.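

Within the data shown here, putting ethyl on the oxygen of the hydroxymethyl group probes that oxygen directly for the first time, and in this assay it gives an at least 1.5-fold higher number from compound 2 to compound 3 (0.18 log units; that floor lies within the scatter). Of the three compounds, only compound 2, with its free hydroxy group, now carries a number, while compound 1 and compound 3 each sit at a limit of the assay. This change therefore has only a floor and no measured size, and the step between compound 1 and compound 3 cannot be read, both values being limits: the limit of > 10 ug/mL in this assay, at which 2 of the 3 values shown sit.

Going by these compounds, how far compound 3 lies past its limit remains open. So does whether a smaller methoxymethyl, an aminomethyl or a carboxylic acid on this same carbon would keep, lower or raise the number seen for compound 2.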